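This account rests on a few compounds, and the source may have more. Where it says the series, first, only, none or still open, it means among the compounds named here.

Working notes on the series

Two compounds of the series have been run in an assay on CHO cells for displacement of a labelled ligand from prostaglandin E2 receptor EP2 subtype (Mus musculus); on this read-out higher numbers stand for weaker inhibition and lower numbers for stronger inhibition. Compound 1 `CCCC[C@H](C)C[C@H](O)/C=C/[C@H]1[C@H](O)CC(=O)[C@@H]1SCCCCCC(=O)O` gives 14 nM in this assay. Compound 2 `COCc1cccc(C[C@H](O)/C=C/[C@H]2[C@H](O)CC(=O)[C@@H]2SCCCSCC(=O)O)c1`, which carries a methoxymethyl-substituted benzyl end on the chain bearing the hydroxyl and a thioether-containing acid side chain, gives 2100 nM in this assay. Compound 2 thus stands at the higher of the two numbers; the gap to compound 1 lies well beyond the usual scatter of repeated measurements. The two compounds differ in several places at once, so no single change can be read out of that gap.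

The next compound, compound 3 `CCOCc1cccc(C[C@H](O)/C=C/[C@H]2[C@H](O)CC(=O)[C@@H]2SCCCSCC(=O)O)c1`, differs from compound 2 in one place only: methyl in place of hydrogen on a saturated chain carbon bound to an oxygen on a saturated carbon, so that methoxymethyl becomes ethoxymethyl. Among the measured compounds shown here, no measured pair shows what such a change does here. The step from compound 2 to compound 3 is expected to be small, a 1.1-fold lower number from compound 2 to compound 3 (0.02 log units; within the scatter), in no particular direction and not beyond the scatter. Compound 3 is therefore estimated at 2000 nM in this assay, with a range from 700 nM to 6000 nM.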

Compound 3, inhibition constant: > 10000 nM
Compound 3 ended at the assay's limit; the forecaster's own chance of this, stated with the estimate: 10%; middle value at least 5.0-fold (0.69 log units) from the limit.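

Methoxymethyl to ethoxymethyl is the first single change that can be read in this series, and it gives an at least 4.7-fold higher number from compound 2 to compound 3 (0.67 log units; beyond the scatter) in this assay, so on this end of the chain bearing the hydroxyl one added methyl, on a saturated chain carbon bound to an oxygen on a saturated carbon, is enough to move the read-out beyond the scatter towards weaker inhibition. For compound 3 the value > 10000 nM is a limit of the assay and not a number. The step therefore gives only the smallest size the change can have, and its full size stays unread: the limit of > 10000 nM in this assay, at which 1 of the 3 values shown sits.

From the compounds shown here alone, whether removing atoms from this end instead, as with hydroxymethyl or a plain methyl group in place of methoxymethyl, gives a lower number than compound 2 stays open, and so does any reading of a longer chain such as propoxymethyl, which could only be compared with a compound at the limit. Also open, going by these compounds, is whether the same methyl step has a similar effect when the acid side chain is the all-carbon chain of compound 1 rather than the thioether-containing one, or when a carboxamide replaces the carboxylic acid.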